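This account rests on a few compounds, and the source may have more. Where it says the series, first, only, none or still open, it means among the compounds named here.

Measured so far in a functional assay on the whole organism for inhibition, with Rattus norvegicus as the target; on this read-out lower numbers stand for an effect already at smaller amounts and higher numbers for an effect only at larger amounts of compound:

Compound 1, `CC1CC/C(=N\Nc2cccc(C(=O)O)c2)c2nccc(=O)n21`, reaches only a limit; in this assay compound 1 gives > 100 umol/kg.
Compound 2, `C[C@H]1CCC(=NNc2ccccc2)c2ncc(C(=O)O)c(=O)n21`, has several entries; in this assay compound 2 gives 1 umol/kg; > 100 umol/kg (2 entries).
Compound 3, `CC1CC/C(=N\Nc2ccc(F)cc2)c2ncc(C(=O)O)c(=O)n21`, reaches only a limit; in this assay compound 3 gives > 1000 umol/kg.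

Compound 3 thus stands at a limit rather than a number, and that limit, (the limit of > 1000 umol/kg in this assay, at which 1 of the 3 values shown sits), is the highest one recorded in the set. The other limit shown, (the limit of > 100 umol/kg in this assay, at which 1 of the 3 values shown sits), sits lower, and the entries of compound 2, (the several entries of compound 2 in this assay, 1 umol/kg; > 100 umol/kg (2 entries)), disagree among themselves, with one number and two limits. Within the data shown here, no step between two measured compounds is computed here, so compound 2 and compound 3 can only be set side by side by their values as given.

Compound 4, `CC1CC/C(=N\Nc2ccccc2O)c2ncc(C(=O)O)c(=O)n21`, is not yet measured. It differs from compound 3 by 2-hydroxyphenyl in place of 4-fluorophenyl on an amine nitrogen. Among the measured compounds shown here, with compound 3 at a limit, there is no measured step on which to build a direction; the expected step of an at least 2.0-fold lower number from compound 3 to compound 4 (0.30 log units; that floor lies within the scatter) is therefore taken as none beyond the scatter, with the result most likely again a limit. The estimate for compound 4 in this assay is 500 umol/kg, within 30 umol/kg to 3000 umol/kg.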

Compound 4, dose for 50% inhibition: > 100 umol/kg
Compound 4 ended at the assay's limit; the forecaster's own chance of this, stated with the estimate: 70%; the middle value does not contradict the limit.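

In this assay, among these compounds, the results for compound 3 and compound 4 are both limits, so no step between them can be read. The compounds shown leave open whether 2-hydroxyphenyl in place of 4-fluorophenyl on an amine nitrogen changes the dose at all, and which entry best describes compound 2: the several entries of compound 2 in this assay, 1 umol/kg; > 100 umol/kg (2 entries)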